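The source may hold more compounds than are shown below. What is called first, only, known or untested is meant among the compounds shown, and "the series" means these compounds.

Measured compounds:
- compound 1, `CC/C(=C(/c1ccc(/C=C/C(=O)O)cc1)c1ccc2c(cnn2C)c1)c1ccc(F)cc1Cl`: 81 nM
- compound 2, `CC/C(=C(/c1ccc(/C=C/C(=O)O)cc1)c1ccc2c(cnn2C)c1)c1ccccc1`: 300 nM
- compound 3, `O=C(O)/C=C/c1ccc(/C(=C(\c2ccccc2)C2CCC2)c2ccc(-c3cncs3)cc2)cc1`: 9.2 nM

All three were run in a functional assay on MCF7 cells (Homo sapiens) for antiproliferative activity, read by CellTiter-Glo, with a stated time of 5 days; on this read-out lower numbers stand for stronger inhibition and higher numbers for weaker inhibition. Compound 2 and compound 1 share a core and differ in one place, (2-chloro-4-fluorophenyl in place of phenyl on a double-bonded chain carbon bound to a double-bonded chain carbon and a saturated chain carbon); that change gave a 3.7-fold lower number from compound 2 to compound 1 (0.57 log units; beyond the scatter). Compound 3 carries a different core; the difference between the two cores is not broken down here. Compound 3 has the lowest number of the three, and its gap to compound 1 lies beyond the scatter.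

Compound 4, `O=C(O)/C=C/c1ccc(/C(=C(\c2ccc(F)cc2Cl)C2CCC2)c2ccc(-c3cncs3)cc2)cc1`, is not yet measured in this assay. It differs from compound 3 by 2-chloro-4-fluorophenyl in place of phenyl on a double-bonded chain carbon bound to a double-bonded chain carbon and a saturated ring carbon. This is the same kind of change as that from compound 2 to compound 1, though the two places are not identical: there the carbon is bound to a saturated chain carbon, here to a saturated ring carbon. Since compound 2 to compound 1 gave a 3.7-fold lower number from compound 2 to compound 1 (0.57 log units; beyond the scatter), a step of similar direction is expected for compound 4, a 3.1-fold lower number from compound 3 to compound 4 (0.49 log units; beyond the scatter), starting from compound 3 at 9.2 nM. The estimate for compound 4 in this assay is 3 nM, with a range of 1.2 nM to 8 nM.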

Compound 4, half-maximal inhibitory concentration: 4.2 nM
The estimate for compound 4 lay 1.4-fold (0.15 log units) below the measured number, and the stated range covers the measured number.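

In this assay, 2-chloro-4-fluorophenyl in place of phenyl lowered the number again on a second core, with a 2.2-fold lower number from compound 3 to compound 4 (0.34 log units; beyond the scatter), so the direction of the change carried over. For the compounds shown here, the sizes of the two steps cannot be told apart: the same change on two cores in this assay, a 3.7-fold lower number (0.57 log units; beyond the scatter) from compound 2 to compound 1 and a 2.2-fold lower number (0.34 log units; beyond the scatter) from compound 3 to compound 4, 1.7-fold (0.23 log units) apart, within the scatter of two such steps This rests on only two matched pairs, and the places differ slightly, with the double-bonded chain carbon bound to a saturated chain carbon in one pair and a saturated ring carbon in the other; it shows neither that the step would hold on further cores nor why the number falls.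

The compounds shown do not separate the two halogens, so 2-chlorophenyl or 4-fluorophenyl alone would be needed to tell how each contributes to the step. As far as these compounds go, all four compounds keep the carboxylic acid, and how a primary amide in its place would read in this assay, with or without the 2-chloro-4-fluorophenyl group, remains open.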